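This account rests on a few compounds, and the source may have more. Where it says the series, first, only, none or still open, it means among the compounds named here.

Compound 1 `COc1ccc(-c2ccc(C)n2-c2ccc(-c3nc4ccc(F)cc4s3)cc2)cc1` in a functional assay on MCF7 cells (Homo sapiens) for cytotoxicity, read by MTT assay, with a stated time of 72 h (a higher number here means a weaker inhibitor, a lower number a stronger inhibitor), gives 2550 nM. Compound 2 `COc1ccc(-c2ccc(C)n2-c2ccc(-c3nc4ccc(OC)cc4s3)cc2)cc1` gives 4830 nM in this assay; the change between them, (methoxy in place of fluoro on an aromatic carbon), made a step of a 1.9-fold higher number from compound 1 to compound 2 (0.28 log units; within the scatter). Compound 3 `COc1cc2nc(-c3ccc(-n4c(C)ccc4-c4ccc(F)cc4)cc3)sc2c(OC)c1OC` gives 2910 nM in this assay; the difference between the core of compound 3 and the core of compound 1 is not broken down here. Compound 4 `COc1ccc(-c2ccc(C)n2-c2ccc(-c3nc4cc(OC)c(OC)c(OC)c4s3)cc2)cc1` is not yet measured in this assay and differs from compound 3 by methoxy in place of fluoro on an aromatic carbon. Among the measured compounds shown here, this is the same kind of change as the one from compound 1 to compound 2, but the place is not the same: here it is on a six-membered aromatic ring of carbon only, para to a large group, whereas there it was part of a fused or bridged system of two rings, meta to a fused ring and para to a fused ring. The expected step is a 1.4-fold higher number from compound 3 to compound 4 (0.14 log units; within the scatter), because a 1.9-fold higher number from compound 1 to compound 2 (0.28 log units; within the scatter) stayed within the scatter. Compound 4 is estimated at 4000 nM, between 1900 nM and 8500 nM.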

Compound 4, half-maximal inhibitory concentration: 2200 nM
Compound 4: the middle estimate sits 1.8-fold (0.26 log units) above what was measured; low and high end bracket the measured number.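

Methoxy in place of fluoro, here 4-fluorophenyl to 4-methoxyphenyl, gives a 1.3-fold lower number from compound 3 to compound 4 (0.12 log units; within the scatter) in this assay. Set beside the earlier case, the two steps cannot be told apart: the same change on two cores in this assay, a 1.9-fold higher number (0.28 log units; within the scatter) from compound 1 to compound 2 and a 1.3-fold lower number (0.12 log units; within the scatter) from compound 3 to compound 4, 2.5-fold (0.40 log units) apart, within the scatter of two such steps. This shows no dependence of the change on the core at the resolution of these data, but it does not show that the two cores respond alike, and two pairs support no general rule for the series.

Open, on these data alone, is whether a different group in the same place, such as an amine, a carboxylic acid or a longer alkoxy chain, would give a step beyond the scatter. Also open, as far as these compounds go, is how these pairs behave in other cell lines.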